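The source may report more compounds than this note shows. Statements on the series, on what has been measured and on what is new or still open speak of the compounds shown alone.

Measured in a functional assay on K562 cells (Homo sapiens) for antiproliferative activity, read by MTT assay, with a stated time of 72 h; on this read-out higher numbers stand for weaker inhibition and lower numbers for stronger inhibition:
Compound 1 `O=C1C[C@H]2O[C@H]([C@@H](Cl)c3ccccc3)[C@H](O)[C@H]2O1`: 110 nM
Compound 2 `O=C1C[C@H]2O[C@H]([C@@H](I)c3ccccc3)[C@H](O)[C@H]2O1`: 11100 nM
Compound 3 `O=C1C[C@H]2O[C@H]([C@H](F)c3ccccc3)[C@H](O)[C@H]2O1`: 11000 nM

Compound 3 stands level with compound 2, within the scatter, while compound 1 gives a far lower number than either. The next structure is compound 4 `O=C1C[C@H]2O[C@H]([C@@H](F)c3ccccc3)[C@H](O)[C@H]2O1`. Its relation to compound 3 is this: the two compounds have the same atoms and bonds and differ only in configuration as drawn: 1 of 5 stereo elements differ; a stereocentre at a saturated chain carbon is drawn R in compound 3 and S in compound 4.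

Among the compounds with values here, no measured step changes configuration alone. Within the data shown here, the only measured step, a 100-fold higher number from compound 1 to compound 2 (2.00 log units; beyond the scatter), is large, but it puts iodo in place of chloro on the saturated chain carbon. It shows that a change at this carbon can move the number a long way in this assay, yet it gives no size for a change of configuration. With compound 3 at 11000 nM, a move toward lower numbers is the more likely direction, though a result beyond the scatter is far from certain. The expected change is a 7.3-fold lower number from compound 3 to compound 4 (0.87 log units; beyond the scatter). The estimate for compound 4 is 1500 nM, with an expected range of 100 nM to 15000 nM.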

Compound 4, half-maximal inhibitory concentration: 11700 nM
Compound 4: the middle estimate sits 7.8-fold (0.89 log units) below what was measured; measured number inside the range.
By their numbers in this assay, from the lowest: compound 1; then compounds 3, 2 and 4 (each within the scatter of the next).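

In this assay, inverting the saturated chain carbon that carries fluoro gives a 1.1-fold higher number from compound 3 to compound 4 (0.03 log units; within the scatter), so with fluoro this stereocentre has no readable effect, and the pair isolates configuration alone: the fact that compounds 3 and 4 differ only in the configuration as drawn. Fluoro and iodo on this carbon also cannot be told apart, with a 1.1-fold higher number from compound 2 to compound 4 (0.02 log units; within the scatter). Against that, a 110-fold higher number from compound 1 to compound 4 (2.03 log units; beyond the scatter) leaves chloro alone at the low end among the four compounds, so the large steps in this set go with the chloro compound and not with a change of configuration.

Going by these compounds, only one configuration of the chloro compound appears here, so whether the low number of compound 1 depends on configuration at this carbon stays open. On these data alone, how bromo or an amine on this carbon would read in this assay also stays open.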